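Chain lengthening in the ring-unsaturated analogue

A few compounds are considered here, and "the series" means these few. Any claim that something is new, unique, unknown or untested is made for them only; others in the source may bear on it.

Compound 2 `O=C(O)CCCC1=CC[C@@H]2[C@@H](/C=C/[C@@H](O)COc3ccccc3)[C@H](O)C[C@@H]2OC1` gives 640 nM in a functional assay on CHO cells for agonist activity at prostaglandin F2-alpha receptor (Homo sapiens), read by fluorescence and calcium flux (a higher number here means that more compound is needed for the effect, a lower number that less compound is needed), the highest of the two numbers recorded; compound 1 `O=C(O)CCC[C@@H]1CC[C@@H]2[C@@H](/C=C/[C@@H](O)COc3ccccc3)[C@H](O)C[C@@H]2O1` gives 4.1 nM in this assay. Compound 3 `O=C(O)CCCCCC1=CC[C@@H]2[C@@H](/C=C/[C@@H](O)COc3ccccc3)[C@H](O)C[C@@H]2OC1` differs from compound 2 by 2-carboxyethyl in place of carboxy on a saturated chain carbon, three bonds along the chain from a double-bonded ring carbon. Within the data shown here, no step of this kind has been measured, so the direction rests on the structural change alone. For compound 3 a moderate rise in the number is expected, a 3.1-fold higher number from compound 2 to compound 3 (0.49 log units; beyond the scatter). The estimate for compound 3 is 2000 nM, with a range from 400 nM to 10000 nM.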

Compound 3, half-maximal effective concentration: 880 nM
Compound 3: middle estimate off by 2.3-fold (0.36 log units), on the high side, and the stated range covers the measured number.
By their numbers in this assay, from the lowest: compound 1; then compounds 2 and 3 (each within the scatter of the next).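

With 2-carboxyethyl in place of carboxy on a saturated chain carbon, three bonds along the chain from a double-bonded ring carbon, a 1.4-fold higher number from compound 2 to compound 3 (0.14 log units; within the scatter) stands in this assay. Among these compounds, this position therefore accepts this extension of the acid chain on the shared core with no difference beyond the scatter, which the earlier compounds could not show. No measured evidence bears on this result.

Still open, on these data alone, is whether a longer chain ending in the carboxylic acid stays level with compound 3. Also open, as far as these compounds go, is whether an amide or a primary alcohol can replace the carboxylic acid at the chain end.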